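A few compounds are considered here, and "the series" means these few. Any claim that something is new, unique, unknown or untested is made for them only; others in the source may bear on it.

Measured compounds:
- compound 1, `Cc1cc(NCCN(C)C)nc2ccc(NC(=O)c3ccc(Cl)c(Cl)c3)cc12`: 2550 nM
- compound 2, `Cc1cc(N(C)C)nc2ccc(NC(=O)c3ccc(Cl)c(Cl)c3)cc12`: 33300 nM
- compound 3, `Cc1cc(N2CCN(C(C)C)CC2)nc2ccc(NC(=O)c3ccc(Cl)c(Cl)c3)cc12`: 1710 nM

All three share one core and differ only in the group attached to it. In a functional assay on MCF7 cells (Homo sapiens) for antiproliferative activity, read by MTT assay, with a stated time of 72 h (on this read-out higher numbers stand for weaker inhibition and lower numbers for stronger inhibition), compound 3 gives the lowest number of the three, yet the gap to compound 1 is small: a 1.5-fold lower number from compound 1 to compound 3 (0.17 log units; within the scatter). The gap to compound 2 is large: a 19-fold lower number from compound 2 to compound 3 (1.29 log units; beyond the scatter).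

Compound 4, `Cc1cc(N2CCCCC2)nc2ccc(NC(=O)c3ccc(Cl)c(Cl)c3)cc12`, has not been measured. It differs from compound 3 in one place: piperidin-1-yl in place of 4-isopropylpiperazin-1-yl on an aromatic carbon. The entering group keeps a six-membered non-aromatic ring but has 1 hetero atom and 1 hydrogen-bond acceptor, where the leaving group had 2 of each; in that respect compound 4 resembles compound 2, whose group also has a single nitrogen. The two steps that bear on this are a 13-fold higher number from compound 1 to compound 2 (1.12 log units; beyond the scatter) and a 19-fold lower number from compound 2 to compound 3 (1.29 log units; beyond the scatter), both large and both pointing to much higher numbers once the second nitrogen is gone. A large rise is therefore expected for compound 4, an 8.8-fold higher number from compound 3 to compound 4 (0.94 log units; beyond the scatter), because of a 19-fold lower number from compound 2 to compound 3 (1.29 log units; beyond the scatter). Compound 4 is estimated at 15000 nM, within 5000 nM to 45000 nM.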

Compound 4, half-maximal inhibitory concentration: 31100 nM
The estimate for compound 4 lay 2.1-fold (0.32 log units) below the measured number; the range from low to high includes it.
By their numbers in this assay, from the lowest: compounds 3 and 1 (each within the scatter of the next); then compounds 4 and 2 (each within the scatter of the next).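

Keeping the six-membered non-aromatic ring does not keep the number low in this assay: replacing 4-isopropylpiperazin-1-yl with piperidin-1-yl gives an 18-fold higher number from compound 3 to compound 4 (1.26 log units; beyond the scatter). The ring itself also shows no readable advantage over the open dimethylamino group, with a 1.1-fold lower number from compound 2 to compound 4 (0.03 log units; within the scatter), while the gap to the group with the longer chain is wide, with a 12-fold higher number from compound 1 to compound 4 (1.09 log units; beyond the scatter). Across these four compounds, the two groups with a second nitrogen give the lower numbers and the two with a single nitrogen the higher ones, none going against this, but no measurement here explains the split.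

This change removes the second ring nitrogen and the isopropyl group together, and the two losses cannot be told apart here. An unsubstituted piperazin-1-yl ring would test the nitrogen without the isopropyl group, and a morpholin-4-yl ring would show whether an oxygen at that ring position can stand in for it.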